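Removing Trifluoromethyl a Second Time, on a Different Core

A few compounds are considered here, and "the series" means these few. Any claim that something is new, unique, unknown or untested is made for them only; others in the source may bear on it.

Compound 1 `O=c1ccc(-c2ccc3cn[nH]c3c2)cn1Cc1cccc(C(F)(F)F)c1` serves as the reference here. In an assay for inhibition of MAP kinase-interacting serine/threonine-protein kinase 1 (Homo sapiens), read by luminescence and ADP-Glo, with a stated time of 2 h (on this read-out higher numbers stand for weaker inhibition and lower numbers for stronger inhibition), compound 1 gives 40 nM. Compound 2 `O=c1ccc(-c2ccc3cn[nH]c3c2)cn1Cc1ccccc1` differs from it by hydrogen in place of trifluoromethyl on an aromatic carbon, and this change produced a 7.9-fold higher number from compound 1 to compound 2 (0.90 log units; beyond the scatter). Compound 3 `Nc1n[nH]c2cc(-c3ccc(=O)n(Cc4cccc(C(F)(F)F)c4)c3)ccc12` stands on a second core, which differs from the core of compound 1 by amino in place of hydrogen on an aromatic carbon; the step of a 1.4-fold higher number from compound 1 to compound 3 (0.15 log units; within the scatter). In this assay compound 3 gives 56 nM, while compound 2 gives 315 nM.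

Compound 4 `Nc1n[nH]c2cc(-c3ccc(=O)n(Cc4ccccc4)c3)ccc12` has not yet been measured. It differs from compound 3 by hydrogen in place of trifluoromethyl on an aromatic carbon, which is the same change that was made from compound 1 to compound 2, at the same place and with the same neighbouring large group. The expected step in this assay from compound 3 to compound 4 is a 7.5-fold higher number from compound 3 to compound 4 (0.88 log units; beyond the scatter), set beside the measured 7.9-fold higher number from compound 1 to compound 2 (0.90 log units; beyond the scatter), because the core step a 1.4-fold higher number from compound 1 to compound 3 (0.15 log units; within the scatter) lies within the scatter and gives no indication that the second core responds differently to the loss of trifluoromethyl. Compound 4 is therefore estimated at 420 nM, with a range from 150 nM to 1200 nM.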

Compound 4, half-maximal inhibitory concentration: 79 nM
Estimate against measurement, compound 4: 5.3-fold (0.73 log units) above, outside the stated range (below it).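

In this assay, hydrogen in place of trifluoromethyl on the core of compound 3 gave a 1.4-fold higher number from compound 3 to compound 4 (0.15 log units; within the scatter), so the large step seen on the core of compound 1 did not carry over to the second core: the same change on two cores in this assay, a 7.9-fold higher number (0.90 log units; beyond the scatter) from compound 1 to compound 2 and a 1.4-fold higher number (0.15 log units; within the scatter) from compound 3 to compound 4, 5.6-fold (0.75 log units) apart, beyond the scatter of two such steps Read the other way, amino in place of hydrogen gave a 4.0-fold lower number from compound 2 to compound 4 (0.60 log units; beyond the scatter) where trifluoromethyl is absent, a step that differs from the one seen where trifluoromethyl is present: the same change on two cores in this assay, a 1.4-fold higher number (0.15 log units; within the scatter) from compound 1 to compound 3 and a 4.0-fold lower number (0.60 log units; beyond the scatter) from compound 2 to compound 4, 5.6-fold (0.75 log units) apart, beyond the scatter of two such steps Across these four compounds, the two changes therefore do not add up independently, but the data do not show why, and a single pair of cores cannot show how far this holds elsewhere in the series.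

From the compounds shown here alone, it remains open whether a chlorine, a methyl or a methoxy group in place of trifluoromethyl would also respond differently on the two cores. Going by these compounds, it is also open whether a hydroxyl or a methylamino group in place of the amino would show the same dependence on trifluoromethyl.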